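This account rests on a few compounds, and the source may have more. Where it says the series, first, only, none or still open, it means among the compounds named here.

Measured compounds:
compound 1 `Nc1ccc2cccc(OCCC(F)(F)F)c2n1` — 722 nM
compound 2 `CCCCOc1cccc2ccc(N)nc12` — 789 nM
compound 3 `CCCOc1cccc2ccc(N)nc12` — 1100 nM

In an assay on cells with melanin-concentrating hormone receptor 1 (Homo sapiens) as the target, read by radioligand binding (on this read-out lower numbers stand for stronger inhibition and higher numbers for weaker inhibition), compound 3 gives 1100 nM, the highest of the three numbers, yet both gaps to it, a 1.5-fold higher number from compound 1 to compound 3 (0.18 log units; within the scatter) and a 1.4-fold higher number from compound 2 to compound 3 (0.14 log units; within the scatter), lie within the scatter, so the three stand level. Compound 4 `Nc1ccc2cccc(OCC3CC3)c2n1` differs from compound 3 by cyclopropyl in place of ethyl on a saturated chain carbon bound to an oxygen on an aromatic ring. All three measured steps, a 1.1-fold higher number from compound 1 to compound 2 (0.04 log units; within the scatter), a 1.5-fold higher number from compound 1 to compound 3 (0.18 log units; within the scatter) and a 1.4-fold higher number from compound 2 to compound 3 (0.14 log units; within the scatter), reshape the same chain beyond the oxygen and none left the scatter, so a cyclopropyl end on that chain is expected to move this assay no further. Compound 4 is therefore estimated at 900 nM, with a range of 400 nM to 2000 nM. That amounts to an expected step of a 1.2-fold lower number from compound 3 to compound 4 (0.09 log units; within the scatter).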

Compound 4, half-maximal inhibitory concentration: > 2000 nM
Compound 4: no number, only a limit (the forecaster's own chance of this, stated with the estimate: 5%); at least 2.2-fold (0.34 log units) between middle value and limit.
By their numbers in this assay, from the lowest: compounds 1, 2 and 3 (each within the scatter of the next). At a limit, above all of these: compound 4.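

In this assay compound 4 gives only a limit, > 2000 nM, and not a number. Even so, cyclopropylmethoxy is the first change shown on this chain to leave the scatter, with an at least 2.5-fold higher number from compound 2 to compound 4 (0.40 log units; beyond the scatter) and an at least 2.7-fold higher number from compound 1 to compound 4 (0.44 log units; beyond the scatter), while the floor of an at least 1.8-fold higher number from compound 3 to compound 4 (0.25 log units; that floor lies within the scatter) stays inside it. The open chains of compounds 1, 2 and 3 stood level, so this position does not accept every chain end alike.

From the compounds shown here alone, how far compound 4 lies beyond its limit remains open. So does whether a cyclobutyl end, a branched isobutyl chain or an amine on the chain would behave like cyclopropyl or like the open chains.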